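From pyridin-2-yl to pyridin-3-yl in compound 2

The compounds below may be only part of what the source reports. "The series", "measured", "known", "first", "only" and "open" are said of these compounds alone.

In a functional assay on A498 cells (Homo sapiens) for antiproliferative activity (a higher number here means a weaker inhibitor of growth, a lower number a stronger inhibitor of growth), compound 2 `c1ccc(-c2cc(-c3ccsc3)cc(-c3ccccn3)n2)nc1` gives 0.000097 ug/mL, the lowest of the three numbers measured. Compound 3 `c1ccc(-c2cc(-c3ccccn3)nc(-c3ccccn3)c2)cc1` gives 0.0025 ug/mL, and compound 1 `c1ccc(-c2cc(-c3cccnc3)nc(-c3ccccn3)c2)cc1` gives 0.074 ug/mL. Compound 4 `c1ccc(-c2cc(-c3ccsc3)cc(-c3cccnc3)n2)nc1` has not yet been measured. It carries pyridin-3-yl in place of pyridin-2-yl on an aromatic carbon of compound 2: pyridin-3-yl in place of pyridin-2-yl on an aromatic carbon. Among the compounds with values here, the only measured pair bearing directly on this exchange shows it in reverse, with phenyl standing where compound 2 has thiophen-3-yl: a 30-fold lower number from compound 1 to compound 3 (1.47 log units; beyond the scatter). Read backwards, that large step predicts a rise in the number. The second measured step, a 26-fold higher number from compound 2 to compound 3 (1.41 log units; beyond the scatter), is the phenyl-for-thiophen-3-yl exchange, and it leads to the same expectation when applied to the value of compound 1. One pair cannot show whether the size carries over to the thiophen-3-yl compounds, so the range is kept wide. The expected change is a 29-fold higher number from compound 2 to compound 4 (1.46 log units; beyond the scatter), a large step beyond the scatter. For compound 4 the estimate is 0.0028 ug/mL, with an expected range from 0.0004 ug/mL to 0.02 ug/mL.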

Compound 4, concentration for 50% growth inhibition: 0.64 ug/mL
Estimate against measurement, compound 4: 230-fold (2.36 log units) below, outside the stated range (above it).
By their numbers in this assay, from the lowest: compound 2; then compound 3; then compound 1; then compound 4.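

In this assay the change to pyridin-3-yl at this position gives a 6600-fold higher number from compound 2 to compound 4 (3.82 log units; beyond the scatter) and so is far larger with thiophen-3-yl on the core than with phenyl, which shows that its size depends on the group carried elsewhere: the same change on two cores in this assay, a 30-fold lower number (1.47 log units; beyond the scatter) from compound 1 to compound 3 and a 6600-fold lower number (3.82 log units; beyond the scatter) from compound 4 to compound 2, 220-fold (2.35 log units) apart, beyond the scatter of two such steps. The exchange of phenyl and thiophen-3-yl also changes direction with the pyridine present, for with pyridin-3-yl the thiophen-3-yl compound now has the higher number, an 8.6-fold higher number from compound 1 to compound 4 (0.94 log units; beyond the scatter): the same change on two cores in this assay, a 26-fold higher number (1.41 log units; beyond the scatter) from compound 2 to compound 3 and an 8.6-fold lower number (0.94 log units; beyond the scatter) from compound 4 to compound 1, 220-fold (2.35 log units) apart, beyond the scatter of two such steps. The two exchanges therefore do not add, and among these four compounds thiophen-3-yl goes with the lower number only alongside pyridin-2-yl.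

The compounds shown leave open whether pyridin-4-yl at this position would behave like pyridin-3-yl. They also leave open whether furan-3-yl in place of thiophen-3-yl would show the same dependence on pyridin-2-yl.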